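Chloro in Place of Fluoro: From Compound 2 to Compound 4

The compounds below may be only part of what the source reports. "The series", "measured", "known", "first", "only" and "open" are said of these compounds alone.

Of the compounds shown here, three have so far been measured in a functional assay, read by spectrophotometry, with a stated time of 15 min, tested at 20 ug/mL; a higher number here means a stronger effect of the compound at the concentration tested, a lower number a weaker effect. Compound 1 `COC(=O)c1cc(-c2csc(N/N=C/c3cccs3)n2)ccc1OCc1ccccc1` gives 94.3%. Compound 3 `Fc1ccc(-c2csc(N/N=C/c3cccs3)n2)cc1` gives 92.4% in this assay. Compound 2 `Fc1ccc(-c2csc(N/N=C/c3ccc(Cl)cc3Cl)n2)cc1` gives 90.7% in this assay; its number is the lowest of the three, but the gaps to compound 3 and to compound 1 both lie within the usual scatter, so the three sit together and none of them can be called stronger or weaker than another.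

Compound 4 `Clc1ccc(-c2csc(N/N=C/c3ccc(Cl)cc3Cl)n2)cc1` has not yet been measured. It differs from compound 2 in one place: chloro in place of fluoro on an aromatic carbon. Among the measured compounds shown here, no measured pair shows this same exchange, so its effect cannot be read from a step already seen; the only guide is where compound 2 sits among its neighbours.

Because compound 2 stands at 90.7%, close to both other compounds, compound 4 is expected to land in the same region of this assay. The expected a number 0.7 percentage points lower from compound 2 to compound 4 (within the scatter) is one that stays within the scatter, in no clear direction. The estimate for compound 4 is 90%, with a range from 80% to 97%.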

Compound 4, a percentage reported as inhibition, at one concentration (the size of the read-out at that concentration, not a potency): 73.9%
Beside the measured number, compound 4's estimate is 16.1 percentage points above it, and the stated range ends above it.
By their numbers in this assay, from the lowest: compound 4; then compounds 2, 3 and 1 (each within the scatter of the next).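

In this assay, among the compounds shown here, the exchange of 4-fluorophenyl to 4-chlorophenyl gives a number 16.8 percentage points lower from compound 2 to compound 4 (beyond the scatter), the first step that can be read as a real difference, since the three earlier compounds sat together and showed nothing about what any single position contributes. It shows that this position, on a six-membered aromatic ring of carbon only and para to a large group, is not indifferent to which halogen it carries: one heavy atom exchanged for another, with no change in ring, donors, acceptors or charge, is enough to move the read-out, although compound 4 still gives 73.9% at the single concentration tested. Why the number falls cannot be said, as nothing measured here bears on the cause of this step.

The compounds shown leave open whether the same exchange would give a similar step in compound 3, whose other end differs, so this single pair cannot yet be called a pattern. They also leave open how this position would respond to a methyl, a methoxy or an amine in place of either halogen.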